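Methylamino in Place of Methoxy: Compound 3 to Compound 4

The source may report more compounds than this note shows. Statements on the series, on what has been measured and on what is new or still open speak of the compounds shown alone.

In an assay on isolated protein for inhibition of transient receptor potential cation channel subfamily A member 1 (Homo sapiens) (on this read-out higher numbers stand for weaker inhibition and lower numbers for stronger inhibition), the measured compounds are:
compound 1 `Cc1cc(S(=O)(=O)N2CCC[C@@H]2c2ccc(F)cc2)cc(C)c1F`: 110 nM
compound 2 `Cc1cc(S(=O)(=O)N2[C@H](CO)CC[C@@H]2c2ccc(F)cc2)cc(C)c1F`: 63 nM
compound 3 `COC[C@@H]1CC[C@H](c2ccc(F)cc2)N1S(=O)(=O)c1cc(C)c(F)c(C)c1`: 270 nM

Compound 3 holds the highest number of the three, shown by a 2.5-fold higher number from compound 1 to compound 3 (0.39 log units; beyond the scatter) and by a 4.3-fold higher number from compound 2 to compound 3 (0.63 log units; beyond the scatter). Compound 4 `CNC[C@@H]1CC[C@H](c2ccc(F)cc2)N1S(=O)(=O)c1cc(C)c(F)c(C)c1` differs from it by methylamino in place of methoxy on a saturated chain carbon bound to a saturated ring carbon. For the measured compounds named here, no measured step exchanges oxygen for nitrogen at this position, so the bearing is indirect: removing the methyl from the oxygen, read backwards, gave a 4.3-fold higher number from compound 2 to compound 3 (0.63 log units; beyond the scatter), and the hydroxymethyl, which like the entering group carries a donor, gave a 1.7-fold lower number from compound 1 to compound 2 (0.24 log units; within the scatter). A modest step towards lower numbers in this assay is therefore expected, with wide uncertainty. Compound 4 is estimated at 150 nM, between 45 nM and 600 nM, which would mean a 1.8-fold lower number from compound 3 to compound 4 (0.26 log units; within the scatter).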

Compound 4, half-maximal inhibitory concentration: > 20000 nM
Compound 4: a limit, no number; the forecaster's own chance of this, stated with the estimate: 5%; at least 130-fold (2.12 log units) between middle value and limit.
By their numbers in this assay, from the lowest: compounds 2 and 1 (each within the scatter of the next); then compound 3. At a limit, above all of these: compound 4.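

Compound 4 carries a limit and no number: the limit of > 20000 nM in this assay, at which 1 of the 4 values shown sits. Earlier changes at this position gave steps no larger than a 4.3-fold higher number from compound 2 to compound 3 (0.63 log units; beyond the scatter), whereas methylamino in place of methoxy gives an at least 74-fold higher number from compound 3 to compound 4 (1.86 log units; beyond the scatter), and the comparisons with the other two compounds give an at least 310-fold higher number from compound 2 to compound 4 (2.50 log units; beyond the scatter) and an at least 180-fold higher number from compound 1 to compound 4 (2.25 log units; beyond the scatter). This position therefore accepts hydrogen, hydroxymethyl and methoxymethyl with modest shifts at most, yet is highly sensitive to replacing the chain oxygen with nitrogen. The compounds shown leave open whether this loss extends to other nitrogen groups, such as a dimethylamino group or an acetamide. They also leave open how a carboxylic acid or a longer ether chain would behave here.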